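Cycloalkylamine variants on a shared core: cyclopentyl to cyclohexyl

The source may hold more compounds than are shown below. What is called first, only, known or untested is meant among the compounds shown, and "the series" means these compounds.

Compound 3 `O=C1C(NC2CCCC2)=CC(=O)c2c1nc1n2[C@H]2OC[C@@H](O)[C@H]2OC1` carries cyclopentyl on the amine nitrogen. In a functional assay on MGC-803 cells (Homo sapiens) for inhibition, read by sulforhodamine B assay (on this read-out lower numbers stand for stronger inhibition and higher numbers for weaker inhibition), compound 3 gives only a limit, > 16000 nM, and no number is known for it; this is the boundary recorded as the limit of > 16000 nM in this assay, at which 1 of the 3 values shown sits. For comparison, compound 1 `COc1cccc(NC2=CC(=O)c3c(nc4n3[C@H]3OC[C@@H](O)[C@H]3OC4)C2=O)c1` gives 1790 nM in this assay. Compound 2 `O=C1C(NC2CC2)=CC(=O)c2c1nc1n2[C@H]2OC[C@@H](O)[C@H]2OC1` likewise ends at a limit in this assay, > 4000 nM, recorded as the limit of > 4000 nM in this assay, at which 1 of the 3 values shown sits. The step of an at least 8.9-fold higher number from compound 1 to compound 3 (0.95 log units; beyond the scatter) and the step of an at least 2.2-fold higher number from compound 1 to compound 2 (0.34 log units; beyond the scatter) both point away from the aryl toward weaker inhibition, while a step that the two limits leave unreadable from compound 2 to compound 3 cannot be sized from two limits. Compound 4 `O=C1C(NC2CCCCC2)=CC(=O)c2c1nc1n2[C@H]2OC[C@@H](O)[C@H]2OC1` differs from compound 3 by cyclohexyl in place of cyclopentyl on an amine nitrogen. Going by the values given here, no measured step of readable size compares two cycloalkyl groups, so the change is expected to stay near the scatter, with compound 4 most likely again reported as a limit. The expected step is a step that the limit leaves unreadable from compound 3 to compound 4. Compound 4 is estimated at 22000 nM, in the range 8000 nM to 60000 nM.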

Compound 4, half-maximal inhibitory concentration: > 8000 nM
Compound 4: no number, only a limit (the forecaster's own chance of this, stated with the estimate: 80%); the middle value does not contradict the limit.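

In this assay compound 4 gives only a limit, > 8000 nM, so cyclohexyl becomes the third cycloalkyl group on the amine nitrogen, after cyclopropyl and cyclopentyl, to end at a limit. Going by these compounds alone, putting cyclohexyl in place of 3-methoxyphenyl gives an at least 4.4-fold higher number from compound 1 to compound 4 (0.65 log units; beyond the scatter), and compound 1 remains the only one of the four compounds with a number. The steps among compound 2, compound 3 and compound 4 cannot be read, and no order of ring size can be stated from limits.

On these data alone, what a plain phenyl or a benzyl group on the amine nitrogen would give in this assay stays open, and with it whether the number for compound 1 goes with the aromatic ring or with its methoxy group. Also open, as far as these compounds go, is how far the true values of compound 2, compound 3 and compound 4 lie from their limits.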